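Amine ring size, compound 3 to compound 4

The compounds below may be only part of what the source reports. "The series", "measured", "known", "first", "only" and "open" are said of these compounds alone.

Three compounds have numbers in an assay on CHO-K1 cells for binding affinity to muscarinic acetylcholine receptor M5 (Homo sapiens); a lower number here means a stronger inhibitor, a higher number a weaker inhibitor. Compound 1 `CSc1ccc2c(c1)C(C(C)c1ccccn1)=C(CCN(C)C)C2` gives 3240 nM. Compound 2 `CC(C1=C(CCN(C)C)Cc2cc(Cl)ccc21)c1ccccn1` gives 724 nM. Compound 3 `CC(C1=C(CCN2CCCCC2)Cc2ccccc21)c1ccccn1` gives 2340 nM, the second highest of the three numbers; its nearest neighbour is compound 1, whose number lies within the scatter of it, while compound 2 sits at a lower number beyond the scatter.

Compound 4 `CC(C1=C(CCN2CCCC2)Cc2ccccc21)c1ccccn1` has not been measured. Its difference from compound 3 is pyrrolidin-1-yl in place of piperidin-1-yl on a saturated chain carbon, two bonds along the chain from a double-bonded ring carbon. Among the measured compounds shown here, no pair of measured compounds shares this change, so no measured step tells its direction; compounds 1, 2 and 3 differ from one another in more than one place and do not isolate the amine ring. The expectation is a step of a 1.3-fold lower number from compound 3 to compound 4 (0.11 log units; within the scatter), not beyond the scatter, with a slight lean toward a lower number. Compound 4 is estimated at 1800 nM, with a range from 600 nM to 5500 nM.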

Compound 4, inhibition constant: 2000 nM
Compound 4: middle estimate off by 1.1-fold (0.05 log units), on the low side, within the range that was stated.
By their numbers in this assay, from the lowest: compound 2; then compounds 4, 3 and 1 (each within the scatter of the next).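

In this assay, among the compounds shown here, the step of a 1.2-fold lower number from compound 3 to compound 4 (0.07 log units; within the scatter) is the only measured step that isolates the amine ring. At this saturated chain carbon, two bonds along the chain from a double-bonded ring carbon, the change from piperidin-1-yl to pyrrolidin-1-yl therefore gives no difference that can be told from the scatter, and the amine ring size tested here does not separate the two compounds. No measurement bearing on the cause of this result is available.

From the compounds shown here alone, whether a morpholin-4-yl or azepan-1-yl group at the same place, or a longer chain carrying the pyrrolidin-1-yl ring, would also leave the number unchanged remains open. Compounds 1, 2 and 3 still differ from one another in more than one place, so the separate contributions of their amines and ring substituents cannot be read.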